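This account rests on a few compounds, and the source may have more. Where it says the series, first, only, none or still open, it means among the compounds named here.

Working notes on the series. The shared core carries a hydroxylated ring and an isopropylidene-bearing chain in each member. Compound 1 `CC(C)=C1C[C@]2(O)[C@@H](C)CC[C@@H]2[C@@](C)(O)CC1=O` and compound 2 `CC(C)=C1C[C@]2(O)[C@@H](CC[C@@H]2C)[C@@](C)(O)CC1=O` are the two bicyclic ketones; compound 3 `C=C(C)[C@@H]1CC[C@](C)(O)[C@H]1CC(C(=O)O)=C(C)C` is the ring-opened acid. In a functional assay on RAW264.7 cells (Mus musculus) for inhibition, read by Griess assay (a higher number here means a weaker inhibitor, a lower number a stronger inhibitor), compound 1 gives 89200 nM and compound 2 gives 92400 nM. Compound 3 gives 68400 nM in this assay, and the values of compound 1 and compound 2 both lie within the scatter of that of compound 3, so the three numbers are not separated.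

Within the data shown here, the only step measured so far between single-site variants is a 1.0-fold higher number from compound 1 to compound 2 (0.02 log units; within the scatter); since (the fact that compounds 1 and 2 differ only in the configuration as drawn), this step shows that inverting two ring stereocentres of the ketone leaves the read-out unchanged within the scatter.

Compound 4 `C=C(C)[C@H]1CC[C@](C)(O)[C@H]1CC(C(=O)O)=C(C)C` is the next compound to be measured. Compared with compound 3, (the two compounds have the same atoms and bonds and differ only in configuration as drawn: 1 of 3 stereo elements differ; a stereocentre at a saturated ring carbon is drawn R in compound 3 and S in compound 4). Among the measured compounds shown here, the step is of the same kind as the one from compound 1 to compound 2: a change of configuration alone. On that basis no movement beyond the scatter is expected, so the step from compound 3 to compound 4 in this assay is expected to be a 1.0-fold higher number from compound 3 to compound 4 (0.01 log units; within the scatter). Compound 4 is therefore estimated to give 70000 nM in this assay, with a range from 30000 nM to 160000 nM.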

Compound 4, half-maximal inhibitory concentration: 66500 nM
Beside the measured number, compound 4's estimate is 1.1-fold (0.02 log units) above it; low and high end bracket the measured number.
By their numbers in this assay, from the lowest: compounds 4, 3, 1 and 2 (each within the scatter of the next).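

The step of a 1.0-fold lower number from compound 3 to compound 4 (0.01 log units; within the scatter) shows that in this assay the ring-opened acid, like the bicyclic ketones, does not move beyond the scatter on a change of configuration alone. The ketone pair differs at two stereo elements at once, whereas this pair differs at a single stereocentre at a saturated ring carbon, so the result isolates that one position and extends the observation to a second structural type in the series. The comparison involves no other change, with nothing entering or leaving: the fact that compounds 3 and 4 differ only in the configuration as drawn.

No step shown so far lies beyond the scatter, so the compounds shown do not identify any structural feature that changes the read-out, and the effect of inverting the remaining stereocentres of the acid on their own stays open. From the compounds shown here alone, it also stays open whether this insensitivity to configuration would persist if the carboxylic acid were replaced by a methyl ester or a primary amide.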